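Aryl substituent series: step from compound 3 to compound 4

The source may hold more compounds than are shown below. What is called first, only, known or untested is meant among the compounds shown, and "the series" means these compounds.

Measured so far in a functional assay on the whole organism for inhibition, with Rattus norvegicus as the target; on this read-out lower numbers stand for an effect already at smaller amounts and higher numbers for an effect only at larger amounts of compound:
- compound 1 `CC1CC/C(=N\Nc2ccc(Br)cc2)c2ncc(C(=O)O)c(=O)n21`: > 1000 umol/kg, a limit of this assay and not a number
- compound 2 `CC1CC/C(=N\Nc2ccc(O)cc2)c2ncc(C(=O)O)c(=O)n21`: > 100 umol/kg, a limit and not a number
- compound 3 `CC1CC/C(=N\Nc2ccc([N+](=O)[O-])cc2)c2ncc(C(=O)O)c(=O)n21`: > 320 umol/kg, a limit and not a number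

Compound 3 stands only at a limit, and the two other values shown are limits as well, so none of the three compounds can be ranked against another. The steps that touch compound 3 are a step that the two limits leave unreadable from compound 1 to compound 3 and a step that the two limits leave unreadable from compound 2 to compound 3; the third step, a step that the two limits leave unreadable from compound 1 to compound 2, is equally unreadable. The limits concerned are the limit of > 100 umol/kg in this assay, at which 1 of the 3 values shown sits, the limit of > 1000 umol/kg in this assay, at which 1 of the 3 values shown sits, and (the limit of > 320 umol/kg in this assay, at which 1 of the 3 values shown sits).

Compound 4 `CC(=O)c1ccc(N/N=C2\CCC(C)n3c2ncc(C(=O)O)c3=O)cc1` differs from compound 3 by acetyl in place of nitro on an aromatic carbon. For the measured compounds named here, no measured step gives a readable size for a change at this position, so no direction beyond the scatter can be expected from the data.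

Compound 4 is therefore expected to sit near or at a limit again in this assay, with an estimate of 1000 umol/kg and a range from 300 umol/kg to 3000 umol/kg. The step from compound 3 to compound 4 is expected to be a step that the limit leaves unreadable from compound 3 to compound 4, that is, nothing readable.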

Compound 4, dose for 50% inhibition: > 100 umol/kg
Compound 4 gave a limit, no number; the forecaster's own chance of this, stated with the estimate: 75%; the middle value is on the limit's open side.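

In this assay compound 4 gives > 100 umol/kg, a limit and not a number. For the compounds shown here, no step from compound 1, compound 2 or compound 3 to compound 4 can be read. The compounds shown leave open how bromo, hydroxy, nitro and acetyl rank in this assay.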